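Halogen placement steps around compound 1

A few compounds are considered here, and "the series" means these few. Any claim that something is new, unique, unknown or untested is made for them only; others in the source may bear on it.

compound 1 `O=C(Nc1ccccc1)c1ccc(C(=O)O)nc1` — 26500 nM
compound 2 `O=C(Nc1cccc(Cl)c1)c1ccc(C(=O)O)nc1` — 32200 nM
compound 3 `O=C(Nc1ccccc1F)c1ccc(C(=O)O)nc1` — 11000 nM

In an assay on isolated protein (Gallus gallus) for inhibition of transmembrane prolyl 4-hydroxylase (Homo sapiens) (on this read-out higher numbers stand for weaker inhibition and lower numbers for stronger inhibition), compound 1 stands second highest of the three numbers, close to compound 2 and furthest from compound 3. Compound 4 `O=C(Nc1ccc(F)cc1)c1ccc(C(=O)O)nc1` differs from compound 1 by fluoro in place of hydrogen on an aromatic carbon. Within the data shown here, two measured steps bear on this change, both single halogen substitutions on the same ring of the shared core: a 2.4-fold lower number from compound 1 to compound 3 (0.38 log units; beyond the scatter) for a fluoro at another position, and a 1.2-fold higher number from compound 1 to compound 2 (0.08 log units; within the scatter) for a chloro. One step was modest and beyond the scatter, the other within it, so only a small shift is expected for compound 4, if any, leaning toward a lower number, a 1.3-fold lower number from compound 1 to compound 4 (0.12 log units; within the scatter). Compound 4 is therefore estimated at 20000 nM, with a range from 8000 nM to 45000 nM.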

Compound 4, half-maximal inhibitory concentration: 16100 nM
For compound 4 the middle estimate is 1.2-fold (0.09 log units) above the measured one, within the range that was stated.
By their numbers in this assay, from the lowest: compounds 3, 4, 1 and 2 (each within the scatter of the next, the first and the last beyond it).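

In this assay, fluoro on an aromatic carbon para to a large group gives a 1.6-fold lower number from compound 1 to compound 4 (0.22 log units; within the scatter) and so stays within the scatter. Among these compounds, of the two fluoro steps from compound 1, only the one to compound 3 lies beyond the scatter, so a lower number with fluoro is not firmly established at this position. Nothing available explains the size of this step.

Open, from the compounds shown here alone, is whether chloro at this same position would behave as fluoro does here. Also open, going by these compounds, is whether a larger group there, such as methoxy or an amine, would move the number beyond the scatter.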